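The source may hold more compounds than are shown below. What is called first, only, known or untested is meant among the compounds shown, and "the series" means these compounds.

In a functional assay on PC-3 cells (Homo sapiens) for cytotoxicity, read by MTT assay, with a stated time of 48 h (on this read-out lower numbers stand for stronger inhibition and higher numbers for weaker inhibition), three compounds have been measured:

compound 1 `CC1=NN(C(=O)CCl)C(c2cc(Br)ccc2O)C1` gives 8890 nM
compound 2 `O=c1oc2ccccc2cc1C1=NN(S(=O)(=O)c2ccc([N+](=O)[O-])cc2)C(c2ccccc2)C1` gives 46600 nM
compound 3 `CCNCC(=O)N1N=C(c2cc3ccccc3oc2=O)CC1c1ccccc1` gives 5580 nM

Compound 3 has the lowest of the three numbers. Its nearest neighbour is compound 1, whose number is higher by an amount within the scatter, so the two cannot be ranked; compound 2 lies far enough above compound 3 to count as a real gap.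

Compound 4 `CCN(CC)C1CCN(CC(=O)N2N=C(c3cc4ccccc4oc3=O)CC2c2ccccc2)CC1` differs from compound 3 in one place: 4-(diethylamino)piperidin-1-yl in place of ethylamino on a saturated chain carbon bound to a carbonyl carbon. Going by the values given here, no measured pair shows a change of this kind, so the expectation can only be a loose one. The author expects a step from compound 3 to compound 4 of a 1.1-fold lower number from compound 3 to compound 4 (0.05 log units; within the scatter), that is, nothing clearly beyond the scatter in either direction. Compound 4 is therefore expected to give about 5000 nM, with a range from 1500 nM to 16000 nM.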

Compound 4, half-maximal inhibitory concentration: 26100 nM
Compound 4: middle estimate off by 5.2-fold (0.72 log units), on the low side, outside the stated range (above it).
By their numbers in this assay, from the lowest: compounds 3 and 1 (each within the scatter of the next); then compounds 4 and 2 (each within the scatter of the next).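

On the saturated chain carbon bound to a carbonyl carbon, this exchange is not neutral: in this assay, 4-(diethylamino)piperidin-1-yl in place of ethylamino gives a 4.7-fold higher number from compound 3 to compound 4 (0.67 log units; beyond the scatter), a step beyond the scatter. Going by these compounds alone, this single pair is the first reading at this position, and here the larger group, which has one six-membered non-aromatic ring and no hydrogen-bond donor, goes with weaker inhibition. No measurement at hand accounts for this loss. Going by these compounds, whether plain piperidin-1-yl or morpholin-4-yl at this place would read like compound 3 or like compound 4 remains open.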